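The source may hold more compounds than are shown below. What is called first, only, known or untested is meant among the compounds shown, and "the series" means these compounds.

Values measured in a functional assay on Bel-7402 cells (Homo sapiens) for antiproliferative activity, read by MTT assay, with a stated time of 72 h (a lower number here means a stronger inhibitor, a higher number a weaker inhibitor), are:

compound 1 `C=C1C(=O)O[C@H]2[C@H]1CC/C(Cn1cc(Cn3cc(F)c(=O)n(Cc4ccc(F)cc4)c3=O)nn1)=C\CC[C@@]1(C)O[C@@H]21` at 4910 nM
compound 2 `C=C1C(=O)O[C@H]2[C@H]1CC/C(COC(=O)Cn1cc(F)c(=O)n(Cc3ccc(F)cc3)c1=O)=C\CC[C@@]1(C)O[C@@H]21` at 2730 nM

These two numbers lie within the usual scatter of repeated measurements, so compound 2 stands level with compound 1 and neither can be ranked above the other.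

Compound 3 `C=C1C(=O)O[C@H]2[C@H]1CC/C(COC(=O)Cn1cc(F)c(=O)n(Cc3cccc(F)c3)c1=O)=C\CC[C@@]1(C)O[C@@H]21` differs from compound 2 by a single change (3-fluorophenyl in place of 4-fluorophenyl on a saturated chain carbon bound to an aromatic nitrogen): the two have the same atoms, joined differently, with 4-fluorobenzyl becoming 3-fluorobenzyl. Among the compounds with values here, no pair of measured compounds shows a change of this kind, so the data offer no direct guide to its size. With nothing pointing either way, no step beyond the scatter is expected in this assay and no direction can be favoured. The expected step of a 1.0-fold lower number from compound 2 to compound 3 (0.00 log units; within the scatter) is therefore an estimate that stays inside the scatter. The reasoning starts from compound 2 at 2730 nM as the closest measured relative. The estimate for compound 3 is 2700 nM within an expected range of 1200 nM to 6000 nM.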

Compound 3, half-maximal inhibitory concentration: 2530 nM
For compound 3 the middle estimate is 1.1-fold (0.03 log units) above the measured one, and the stated range covers the measured number.
By their numbers in this assay, from the lowest: compounds 3, 2 and 1 (each within the scatter of the next).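

Within the data shown here, the swap of 4-fluorobenzyl for 3-fluorobenzyl is the first change confined to one place, and in this assay it amounts to a 1.1-fold lower number from compound 2 to compound 3 (0.03 log units; within the scatter), the only step that can be read so far. At this position, on a saturated chain carbon bound to an aromatic nitrogen, 3-fluorophenyl and 4-fluorophenyl therefore cannot be told apart in this measurement, something compound 1 and compound 2 could not show, as they do not differ in one place only. Nothing measured here explains this result.

The compounds shown all carry a fluorine on this phenyl ring, so they leave open whether a plain benzyl group without fluorine would read any differently from compound 2 and compound 3. They also leave open whether a larger departure at the same place, such as a carboxylic acid or an amine on the ring, or a longer chain between the ring and the aromatic nitrogen, would produce a step beyond the scatter.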